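The source may hold more compounds than are shown below. What is called first, only, known or untested is meant among the compounds shown, and "the series" means these compounds.

Compound 1 `CC1(C)C(C(N)=O)C1(C)C` — 57 mg/kg in a functional assay on the whole organism with Mus musculus as the target; a lower number here means that less compound is needed, a higher number that more compound is needed for the effect
Compound 2 `CNC(=O)C1C(C)(C)C1(C)C` — 39 mg/kg in this assay

Compound 2 has the lowest of the two numbers in this assay; its neighbour is compound 1, and the step of a 1.5-fold lower number from compound 1 to compound 2 (0.16 log units; within the scatter) lies within the scatter, so the two compounds cannot be ordered. Compound 3 `CC1(C)C(C(=O)NCC(N)=O)C1(C)C` takes the next step from compound 2: carbamoyl in place of hydrogen on a saturated chain carbon bound to an amide-type nitrogen. Among the measured compounds shown here, the only step that bears on this change is a 1.5-fold lower number from compound 1 to compound 2 (0.16 log units; within the scatter), a change at the amide-type nitrogen that produced no shift beyond the scatter. On that basis the step of a 1.2-fold higher number from compound 2 to compound 3 (0.06 log units; within the scatter) in this assay is expected to stay within the scatter, in no particular direction. For compound 3 in this assay the estimate is 45 mg/kg, with a range from 20 mg/kg to 100 mg/kg.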

Compound 3, dose for half-maximal effect: 115 mg/kg
Beside the measured number, compound 3's estimate is 2.6-fold (0.41 log units) below it; measured number outside the range, above it.
By their numbers in this assay, from the lowest: compounds 2, 1 and 3 (each within the scatter of the next, the first and the last beyond it).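

Carbamoyl in place of hydrogen on the saturated chain carbon bound to the amide-type nitrogen gives the first change at this position beyond the scatter in this assay, with a 2.9-fold higher number from compound 2 to compound 3 (0.47 log units; beyond the scatter) as a modest step. Read against the unsubstituted amide, carbamoylmethyl in place of hydrogen on that nitrogen gives a 2.0-fold higher number from compound 1 to compound 3 (0.30 log units; within the scatter) and stays within the scatter, so the shift appears only against the methyl amide. No measurement here bears on the reason for this shift.

From the compounds shown here alone, whether a longer chain on this nitrogen would behave like methyl or like carbamoylmethyl stays open. So does the outcome with an amine or a carboxylic acid in place of carbamoyl.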